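The source may hold more compounds than are shown below. What is called first, only, known or untested is meant among the compounds shown, and "the series" means these compounds.

In a functional assay on HT-29 cells (Homo sapiens) for antiproliferative activity, read by MTT assay, with a stated time of 72 h, tested at 10 uM (on this read-out lower numbers stand for less inhibition and higher numbers for more inhibition at the one concentration tested (going by the name of the read-out)), compound 1 `O=C(Nc1cc(Oc2ccc(Nc3nccc4[nH]cc(-c5ccc(F)cc5)c(=O)c34)cc2F)ccn1)C1CCC1` gives 46%, compound 2 `CC(O)C(=O)Nc1cc(Oc2ccc(Nc3nccc4[nH]cc(-c5ccc(F)cc5)c(=O)c34)cc2F)ccn1` gives 47.8%, and compound 3 `CCCC(=O)Nc1cc(Oc2ccc(Nc3nccc4[nH]cc(-c5ccc(F)cc5)c(=O)c34)cc2F)ccn1` gives 23.5%. Compound 3 stands lowest of the three numbers, as shown by a number 22.5 percentage points lower from compound 1 to compound 3 (beyond the scatter) and by a number 24.3 percentage points lower from compound 2 to compound 3 (beyond the scatter), whereas a number 1.8 percentage points higher from compound 1 to compound 2 (within the scatter). Compound 4 `O=C(CO)Nc1cc(Oc2ccc(Nc3nccc4[nH]cc(-c5ccc(F)cc5)c(=O)c34)cc2F)ccn1` is reached from compound 3 by hydroxy in place of ethyl on a saturated chain carbon bound to a carbonyl carbon. The measured step that bears on this is a number 24.3 percentage points lower from compound 2 to compound 3 (beyond the scatter), which ran the opposite way when propyl replaced 1-hydroxyethyl; putting a hydroxy-bearing chain back on the carbonyl carbon is therefore expected to undo most of that loss, with an expected rise of a number 18.5 percentage points higher from compound 3 to compound 4 (beyond the scatter) in this assay. Compound 4 is accordingly estimated to give about 42%, in a range from 26% to 58%.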

Compound 4, a percentage reported as inhibition, at one concentration (the size of the read-out at that concentration, not a potency): 18.5%
Beside the measured number, compound 4's estimate is 23.5 percentage points above it; measured number outside the range, below it.
By their numbers in this assay, from the lowest: compounds 4 and 3 (each within the scatter of the next); then compounds 1 and 2 (each within the scatter of the next).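

In this assay, a hydroxy on the saturated chain carbon bound to a carbonyl carbon is not enough on its own to hold the read-out: a number 5 percentage points lower from compound 3 to compound 4 (within the scatter) leaves hydroxymethyl and propyl within the scatter of each other. The methyl of the 1-hydroxyethyl group matters here, since a number 29.3 percentage points lower from compound 2 to compound 4 (beyond the scatter), and hydroxymethyl also falls short of cyclobutyl, with a number 27.5 percentage points lower from compound 1 to compound 4 (beyond the scatter). Nothing measured here gives a reason for this. As far as these compounds go, whether an amine or a carboxylic acid at this carbon would side with compound 2 or compound 4 remains open.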